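Urea aryl exchange: chloro to trifluoromethyl in a pyrazole series

A few compounds are considered here, and "the series" means these few. Any claim that something is new, unique, unknown or untested is made for them only; others in the source may bear on it.

Measured compounds:
compound 1 `COc1cc(-c2nn(-c3cccc(NC(=O)Nc4ccc(Cl)c(Cl)c4)c3)cc2-c2ccncc2)ccc1Cl` gives 3020 nM
compound 2 `O=C(Nc1cccc(-n2cc(-c3ccncc3)c(-c3ccc(Cl)c(O)c3)n2)c1)Nc1ccc(Cl)c(Cl)c1` gives 2350 nM
compound 3 `O=C(Nc1cccc(-n2cc(-c3ccncc3)c(-c3ccc(Cl)c(O)c3)n2)c1)Nc1cc(C(F)(F)F)cc(C(F)(F)F)c1` gives 2620 nM

In a functional assay on SK-MEL-5 cells (Homo sapiens) for inhibition, read by sulforhodamine B assay, with a stated time of 48 h (on this read-out lower numbers stand for higher toxicity in this test and higher numbers for lower toxicity in this test), compound 1 stands at the highest of the three numbers, yet its gaps to compound 3 and to compound 2 are both within the scatter, so no order among the three can be read. Among the measured compounds shown here, the only single-point step available, a 1.3-fold lower number from compound 1 to compound 2 (0.11 log units; within the scatter), concerns the oxygen on an aromatic ring and does not touch the urea end of the molecule. For the measured compounds named here, compound 2 and compound 3 differ in the aryl group on the urea, but no computed step joins them; what their two values show is that compound 2 gives 2350 nM and compound 3 gives 2620 nM, two numbers lying close together.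

Compound 4 `COc1cc(-c2nn(-c3cccc(NC(=O)Nc4ccc(Cl)c(C(F)(F)F)c4)c3)cc2-c2ccncc2)ccc1Cl` arises from compound 1 by trifluoromethyl in place of chloro on an aromatic carbon. Nothing measured covers this exact exchange; both the methyl step and the comparison of compound 2 with compound 3 left the numbers near one another. No step beyond the scatter is therefore expected in this assay for compound 4, which is estimated at 3000 nM (range 1500 nM to 6000 nM). The expected step of a 1.0-fold lower number from compound 1 to compound 4 (0.00 log units; within the scatter) thus stays within the scatter.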

Compound 4, concentration lethal to 50% of the cells: 10400 nM
For compound 4 the middle estimate is 3.5-fold (0.54 log units) below the measured one, and the stated range ends below it.
By their numbers in this assay, from the lowest: compounds 2, 3 and 1 (each within the scatter of the next); then compound 4.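

In this assay, among the compounds shown here, the aryl group on the urea is the first place in this set where a single exchange moves the number beyond the scatter, with a 3.4-fold higher number from compound 1 to compound 4 (0.54 log units; beyond the scatter), whereas a 1.3-fold lower number from compound 1 to compound 2 (0.11 log units; within the scatter) at the oxygen on the aromatic ring stays within it. The higher number means lower toxicity in this test, so going from 3,4-dichlorophenyl to 4-chloro-3-(trifluoromethyl)phenyl matters here, even with the chloro group left in place and only its ortho neighbour exchanged. This holds for one pair only, on the core of compound 1 with methyl on the oxygen, and nothing shown accounts for the step.

As far as these compounds go, it remains open whether the same exchange gives a step of similar size on compound 2 , where hydrogen stands in place of that methyl. Also open, from the compounds shown here alone, is whether the step is particular to trifluoromethyl or would also follow from a nitrile, a methyl group or an amine on the same aromatic carbon.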